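Bromophenol coumarin amines: pyrrolidine in place of dimethylamino

This account rests on a few compounds, and the source may have more. Where it says the series, first, only, none or still open, it means among the compounds named here.

Compound 1 `O=C(CCN1CCCC1)c1cc2ccc(O)cc2oc1=O` and compound 2 `CN(C)CCC(=O)c1cc2cc(Br)c(O)c(Br)c2oc1=O` have both been run in an assay on cells for inhibition of Amine oxidase [flavin-containing] B (Homo sapiens), read by fluorescence, spectrophotometry and Amplex Red, with stated times of 60 min and 30 min; a lower number here means a stronger inhibitor, a higher number a weaker inhibitor. In this assay compound 1 gives only a limit, > 200000 nM. Compound 2 likewise gives only a limit, > 200000 nM. Both values sit at the limit of > 200000 nM in this assay, at which 2 of the 2 values shown sit, so compound 2 stands at the limit with no number to rank against. Compound 3 `O=C(CCN1CCCC1)c1cc2cc(Br)c(O)c(Br)c2oc1=O` is not yet measured; it differs from compound 2 by pyrrolidin-1-yl in place of dimethylamino on a saturated chain carbon, two bonds along the chain from a carbonyl carbon. For the measured compounds named here, with no measured step available, the expected step that the limit leaves unreadable from compound 2 to compound 3 is none beyond the scatter. Compound 3 is accordingly estimated at 300000 nM, between 150000 nM and 1000000 nM, and is expected most likely to be reported again only as a limit.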

Compound 3, half-maximal inhibitory concentration: > 200000 nM
Compound 3: only a limit was reported (the forecaster's own chance of this, stated with the estimate: 85%); the middle value does not contradict the limit.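

Compound 2 and compound 3 both give only a limit in this assay, so no step can be read between them: the limit of > 200000 nM in this assay, at which 3 of the 3 values shown sit.

The compounds shown leave open whether pyrrolidin-1-yl and dimethylamino differ at all, and which change to the shared core would give a readable number.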